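Clearance notes: hydroxy for dimethylamino on the chain

The source may hold more compounds than are shown below. What is called first, only, known or untested is meant among the compounds shown, and "the series" means these compounds.

Compound 3 `CN(C)CCNc1ccc(Cn2c(=O)[nH]c3c(N)nc(C(F)(F)F)cc32)cn1` gives 16 mL.min-1.g-1 in an in vitro ADME assay on microsomes from liver (Rattus norvegicus) for pharmacokinetics; on this read-out lower numbers stand for slow clearance and higher numbers for fast clearance. For the measured compounds named here, compound 2 `Nc1nc(C(F)(F)F)cc2c1[nH]c(=O)n2Cc1ccc(NCCN2CCCCC2)nc1` gives 16 mL.min-1.g-1 in this assay, and the step of no change at the digits printed from compound 2 to compound 3 (within the scatter) leaves the two level, so compound 3 stands with compound 2 among the numbers measured so far. For compound 1 `CN(C)CCN1CCN(c2ccc(Cn3c(=O)[nH]c4c(N)nc(C(F)(F)F)cc43)cn2)CC1` the assay reports only a limit, < 8.5 mL.min-1.g-1. The steps of an at least 1.8-fold higher number from compound 1 to compound 2 (0.27 log units; that floor lies within the scatter) and an at least 1.8-fold higher number from compound 1 to compound 3 (0.27 log units; that floor lies within the scatter) rest on that limit, as the limit of < 8.5 mL.min-1.g-1 in this assay, at which 1 of the 3 values shown sits, records, and they carry no more weight than a floor within the scatter.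

The next compound, compound 4 `Nc1nc(C(F)(F)F)cc2c1[nH]c(=O)n2Cc1ccc(NCCO)nc1`, differs from compound 3 in one place: hydroxy in place of dimethylamino on a saturated chain carbon, two bonds along the chain from a nitrogen on an aromatic ring. Among the measured steps only the pair from compound 2 to compound 3 alters this chain position, and there no change at the digits printed from compound 2 to compound 3 (within the scatter) left the number unchanged. Going by the values given here, no measured step exchanges dimethylamino for hydroxy, so a direct precedent is missing. On the strength of the flat step at the same position, the expected change for compound 4 is a 1.1-fold lower number from compound 3 to compound 4 (0.06 log units; within the scatter) in this assay, that is, nothing beyond the scatter. Compound 4 is therefore estimated at 14 mL.min-1.g-1, with an expected range from 7 mL.min-1.g-1 to 28 mL.min-1.g-1.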

Compound 4, intrinsic clearance in microsomes: < 8.5 mL.min-1.g-1
Compound 4: no number, only a limit; the forecaster's own chance of this, stated with the estimate: 20%; middle value at least 1.6-fold (0.21 log units) away from the limit.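

In this assay compound 4 reports only a limit, < 8.5 mL.min-1.g-1. For the compounds shown here, the steps of an at least 1.8-fold lower number from compound 3 to compound 4 (0.27 log units; that floor lies within the scatter) and an at least 1.8-fold lower number from compound 2 to compound 4 (0.27 log units; that floor lies within the scatter) are the first at this chain position to point in any direction, after piperidin-1-yl and dimethylamino had stood level, though each is only a floor and does not show a change beyond the scatter. Compound 1 and compound 4 rest on the same limit, so the step between them cannot be read, and the full size of the exchange to hydroxy stays unknown: the limit of < 8.5 mL.min-1.g-1 in this assay, at which 2 of the 4 values shown sit.

The compounds shown leave open whether hydroxy is particular in this respect, or whether a methoxy group, a primary amine or a carboxylic acid on the same saturated chain carbon would also stand with compound 4 rather than with compound 3. Also open, going by these compounds, is whether a longer chain ending in hydroxy would stay at the limit or return to the level shared by compound 2 and compound 3.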